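Aryl amide variation on the chromone acid core

The source may report more compounds than this note shows. Statements on the series, on what has been measured and on what is new or still open speak of the compounds shown alone.

Three amides of the shared core have been measured in an assay on CHO cells for agonist activity at G protein-coupled receptor GPR35 (Rattus norvegicus), read by a beta-galactosidase reporter and beta-arrestin recruitment, with a stated time of 90 min; on this read-out lower numbers stand for an effect already at smaller amounts and higher numbers for an effect only at larger amounts of compound. Compound 1 `Cc1cccc(C(=O)Nc2cc(Cl)cc3c(=O)cc(C(=O)O)oc23)c1` carries a 3-methylphenyl group on the carbonyl carbon and gives 2100 nM. Compound 3 `O=C(Nc1cc(Cl)cc2c(=O)cc(C(=O)O)oc12)c1ccc([N+](=O)[O-])cc1` carries a 4-nitrophenyl group there and gives 3140 nM. Compound 2 `COc1ccc(C(=O)Nc2cc(Br)cc3c(=O)cc(C(=O)O)oc23)cn1` carries a 6-methoxypyridin-3-yl group and gives 991 nM, the lowest of the three numbers; both compound 1 and compound 3 lie beyond the scatter above it.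

The next compound is compound 4 `N#Cc1ccc(C(=O)Nc2cc(Br)cc3c(=O)cc(C(=O)O)oc23)cc1`, which differs from compound 2 in one place: 4-cyanophenyl in place of 6-methoxypyridin-3-yl on a carbonyl carbon. Among the compounds with values here, the only measured step of the same kind, an exchange of the aryl group on the carbonyl carbon, is a 1.5-fold higher number from compound 1 to compound 3 (0.17 log units; within the scatter), a change within the scatter. That step, however, concerns two carbon-only rings and a chloro core, whereas compound 2 holds a pyridine ring on a bromo core, so the comparison is loose. Within the data shown here, with only one relevant step and no spread beyond the scatter in it, the expectation for compound 4 is a small rise in number, if any, toward the values of compound 1 and compound 3. Compound 4 is therefore estimated at 1500 nM, with a range from 600 nM to 4000 nM. This estimate corresponds to an expected step of a 1.5-fold higher number from compound 2 to compound 4 (0.18 log units; within the scatter).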

Compound 4, half-maximal effective concentration: 2260 nM
Beside the measured number, compound 4's estimate is 1.5-fold (0.18 log units) below it, within the range that was stated.
By their numbers in this assay, from the lowest: compound 2; then compounds 1, 4 and 3 (each within the scatter of the next).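

In this assay, the aryl group on the carbonyl carbon now gives a step beyond the scatter, a 2.3-fold higher number from compound 2 to compound 4 (0.36 log units; beyond the scatter), whereas the earlier exchange at this place, a 1.5-fold higher number from compound 1 to compound 3 (0.17 log units; within the scatter), stayed within it. The position is therefore not indifferent to the aryl group, at least on the core shared by compound 2 and compound 4: with the heavy-atom count unchanged, the 6-methoxypyridin-3-yl group gives the lower number and the 4-cyanophenyl group the higher one. No measurement at hand accounts for this step.

The exchange alters the ring hetero atom and the substituent together, so the lower number of compound 2 cannot yet be assigned to the ring nitrogen or to the methoxy group. A 4-methoxyphenyl group and an unsubstituted pyridin-3-yl group on the carbonyl carbon of the same core would separate these two contributions, and the same exchange on the chloro-bearing core of compound 1 would show whether the step carries over.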